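The source may report more compounds than this note shows. Statements on the series, on what has been measured and on what is new or still open speak of the compounds shown alone.

Working notes on the shared core of compound 1 `CCCOC(=O)c1nc(C)c2c(c1N)C(=O)N(Cc1ccccc1)C2=O`, compound 2 `Cc1nc(-c2nc(C(F)(F)F)no2)c(N)c2c1C(=O)N(Cc1ccccc1)C2=O` and compound 3 `Cc1noc(-c2nc(C)c3c(c2N)C(=O)N(Cc2ccc(OC(F)(F)F)cc2)C3=O)n1`, read against the unmeasured compound 4 `Cc1noc(-c2nc(C)c3c(c2N)C(=O)N(Cc2ccc(S(C)(=O)=O)cc2)C3=O)n1`. In a physicochemical assay for solubility, using the shake flask method, in simulated intestinal fluid, measured as kinetic solubility, with a stated time of 2 h, at 25 degrees C, at pH 6.5 (a lower number here means a less soluble compound, a higher number a more soluble compound), compound 1 gives < 5000 nM, which is a limit of the assay and not a number. In this assay compound 2 gives < 5000 nM, again a limit. In this assay compound 3 gives < 5000 nM, also a limit. Within the data shown here, the only step between measured compounds, a step that the two limits leave unreadable from compound 1 to compound 2, is therefore of unreadable size and direction. Compound 3 thus stands at the same limit as the other two; (the limit of < 5000 nM in this assay, at which 3 of the 3 values shown sit).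

Compound 4 differs from compound 3 by methylsulfonyl in place of trifluoromethoxy on an aromatic carbon. Among the measured compounds shown here, no measured step changes the group at this place, and the one measured step exchanges a different group of the core, so none of the measured data gives a readable size or direction for this assay here. The expectation is that compound 4 stays close to the limit in this assay, with an estimated step of a number no lower from compound 3 to compound 4 (the limit leaves the size open) that is not more than the scatter. Compound 4 is estimated at 5000 nM, between 800 nM and 40000 nM, with a real chance that only a limit is reported.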

Compound 4, solubility: < 5000 nM
Compound 4 gave a limit, no number; the forecaster's own chance of this, stated with the estimate: 55%; the middle value sits exactly at the limit.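

The step from compound 3 to compound 4 in this assay cannot be read, since both compounds give only a limit of the assay and not a number: the limit of < 5000 nM in this assay, at which 4 of the 4 values shown sit.

The compounds shown leave open where the true values of compound 1, compound 2, compound 3 and compound 4 lie, and so what methylsulfonyl in place of trifluoromethoxy does in this assay.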